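Working notes: tert-butoxycarbonyl for ethyl on the chain

The compounds below may be only part of what the source reports. "The series", "measured", "known", "first", "only" and "open" are said of these compounds alone.

Compound 2 `CCCCNc1oc2c(C)ncc(CO)c2c1Nc1ccccn1` is read in a functional assay on HEK293 cells for agonist activity at Toll-like receptor 8 (Homo sapiens), read by reporter gene assay (on this read-out higher numbers stand for an effect only at larger amounts of compound and lower numbers for an effect already at smaller amounts), where compound 2 gives 9380 nM. That is the higher of the two numbers at hand: compound 3 `CCCCCNc1oc2c(C)ncc(CO)c2c1Nc1ccccc1` gives 2250 nM in this assay, and the gap between them lies beyond the scatter, so compound 3 acts already at smaller amounts than compound 2. Compound 1 `Cc1ncc(CO)c(-c2nc3ccccn3c2NC2CCCCC2)c1OCc1ccccc1` has a core that differs from the core of compound 2. In this assay compound 1 is recorded as "not active" (no number reported), with no number reported.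

Within the data shown here, no two measured compounds differ in one place only, so nothing measured tracks the change leading to compound 4 `Cc1ncc(CO)c2c(Nc3ccccn3)c(NCCC(=O)OC(C)(C)C)oc12`. That change is tert-butoxycarbonyl in place of ethyl on a saturated chain carbon, two bonds along the chain from a nitrogen on an aromatic ring. Compounds 2 and 3 differ in more than one place, so their gap cannot be assigned to the chain alone.

Among the measured compounds shown here, with no comparable step available, a modest step in this assay is expected, direction uncertain, estimated as a 1.2-fold lower number from compound 2 to compound 4 (0.07 log units; within the scatter). For compound 4 the expected value in this assay is 8000 nM, within 2000 nM to 30000 nM.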

Compound 4, half-maximal effective concentration: 7640 nM
Beside the measured number, compound 4's estimate is 1.0-fold (0.02 log units) above it; measured number inside the range.
By their numbers in this assay, from the lowest: compound 3; then compounds 4 and 2 (each within the scatter of the next).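

Among these compounds, this is the first one-place comparison: in this assay, tert-butoxycarbonyl in place of ethyl on a saturated chain carbon, two bonds along the chain from a nitrogen on an aromatic ring, gives a 1.2-fold lower number from compound 2 to compound 4 (0.09 log units; within the scatter). At this place, therefore, the read-out does not separate the small ethyl group from the much larger tert-butoxycarbonyl group, which also brings in a carbonyl and hydrogen-bond acceptors. No measurement at hand speaks to why the two groups read alike.

On these data alone, whether the same holds for a free carboxylic acid, an amide or an amine at this place remains open. Also open, as far as these compounds go, is whether a longer chain carrying the same ester would stay within the scatter of compound 2 in this assay.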